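The source may hold more compounds than are shown below. What is called first, only, known or untested is meant among the compounds shown, and "the series" means these compounds.

Compound 1 `COc1cc(-c2nn(-c3cccc(NC(=O)Nc4cc(C(F)(F)F)cc(C(F)(F)F)c4)c3)cc2-c2ccncc2)ccc1Cl`: in a functional assay on M14 cells (Homo sapiens) for inhibition, read by sulforhodamine B assay, with a stated time of 48 h (a higher number here means a weaker inhibitor of growth, a lower number a stronger inhibitor of growth), compound 1 gives 2550 nM.
Compound 2 `COc1cc(-c2nn(-c3cccc(NC(=O)c4cccc(C(F)(F)F)c4)c3)cc2-c2ccncc2)ccc1Cl`: in this assay compound 2 gives > 50000 nM, which is a limit of the assay and not a number.

The two measured compounds share a core and differ only in the group attached to the anilide nitrogen. In this assay compound 1 gives 2550 nM. Compound 2 reaches only a limit, namely (the limit of > 50000 nM in this assay, at which 1 of the 2 values shown sits), so where compound 2 stands on the scale is not known beyond that bound. The unmeasured compound 3 `COc1cc(-c2nn(-c3cccc(NC(=O)c4ccc(Cl)c(C(F)(F)F)c4)c3)cc2-c2ccncc2)ccc1Cl` keeps the benzamide of compound 2 and changes it in one place: chloro in place of hydrogen on an aromatic carbon, in words chloro in place of hydrogen on an aromatic carbon. Among the measured compounds shown here, no step between measured compounds is available to set the size of this change, and since compound 2 sits at a limit the direction cannot be read from the numbers either. One expects the step of an at least 2.0-fold lower number from compound 2 to compound 3 (0.30 log units; that floor lies within the scatter) to be a gain of modest size, with a fair chance that a limit is reported again. For compound 3 in this assay the estimate is 25000 nM, expected to lie between 5000 nM and 50000 nM.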

Compound 3, concentration for total growth inhibition: > 32500 nM
Compound 3 was reported as a limit; the forecaster's own chance of this, stated with the estimate: 50%; at least 1.3-fold (0.11 log units) between middle value and limit.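

In this assay compound 2 gives > 50000 nM as a limit of the assay and not a number. Among the compounds shown here, compound 3 gives > 32500 nM as a limit too, so no step from compound 2 to compound 3 can be read. Still open, going by these compounds, is whether chloro in place of hydrogen on the aromatic carbon changes growth inhibition at all.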